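The source may hold more compounds than are shown below. What is called first, only, known or untested is meant among the compounds shown, and "the series" means these compounds.

Measured so far in a functional assay on T47D cells (Homo sapiens) for cytotoxicity, read by MTT assay, with a stated time of 24 h; on this read-out lower numbers stand for stronger inhibition and higher numbers for weaker inhibition:
compound 1 `COc1cccc(-n2cc(COc3c(/C=C\C(=O)O)ccc(OC)c3CC=C(C)C)nn2)c1` gives 20400 nM;
compound 2 `COc1ccc(/C=C\C(=O)O)c(OCc2cn(-c3ccccc3)nn2)c1CC=C(C)C` gives 34100 nM;
compound 3 `COc1ccc(/C=C\C(=O)O)c(OCc2cn(-c3ccc(CO)cc3)nn2)c1CC=C(C)C` gives 40000 nM.

Compound 3 carries the highest of the three numbers, though every gap to it is within the scatter, so no order among the three can be read. Compound 4 `COc1ccc(/C=C\C(=O)O)c(OCc2cn(-c3nc4ccccc4s3)nn2)c1CC=C(C)C` differs from compound 3 only at the group on the triazole nitrogen: 1,3-benzothiazol-2-yl in place of 4-(hydroxymethyl)phenyl on an aromatic nitrogen. Going by the values given here, the steps that bear on this place are a 2.0-fold higher number from compound 1 to compound 3 (0.29 log units; within the scatter) and a 1.2-fold higher number from compound 2 to compound 3 (0.07 log units; within the scatter), each a change of the same aryl group, and neither left the scatter. On that basis compound 4 is expected to sit in the same band, with a 1.1-fold lower number from compound 3 to compound 4 (0.06 log units; within the scatter) as the expected step. Compound 4 is therefore estimated at 35000 nM, within 15000 nM to 80000 nM.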

Compound 4, half-maximal inhibitory concentration: 17200 nM
Beside the measured number, compound 4's estimate is 2.0-fold (0.31 log units) above it; the measured number falls inside the stated range.
By their numbers in this assay, from the lowest: compounds 4, 1, 2 and 3 (each within the scatter of the next, the first and the last beyond it).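

In this assay, going by these compounds alone, 1,3-benzothiazol-2-yl on the aromatic nitrogen gives the first step at this position beyond the scatter, with a 2.3-fold lower number from compound 3 to compound 4 (0.37 log units; beyond the scatter) showing that this group can shift the number, though modestly. That separation holds only against 4-(hydroxymethyl)phenyl, since a 2.0-fold lower number from compound 2 to compound 4 (0.30 log units; within the scatter) and a 1.2-fold lower number from compound 1 to compound 4 (0.07 log units; within the scatter) both stay within the scatter. No data on hand account for the step.

On these data alone, whether an amine or a longer alkyl chain in place of the aromatic group on this nitrogen would keep the number in this range remains open.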